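Imine on a Shared Core: Expected Tolerance on Liver Cells

The source may report more compounds than this note shows. Statements on the series, on what has been measured and on what is new or still open speak of the compounds shown alone.

Going by the values given here, compound 3 `C(=C/c1ccccc1)\C=N\c1sc2c(c1-c1nc3ccccc3s1)CCCC2` carries the largest of the three numbers so far in an ADME assay on HepG2 cells (Homo sapiens) for cytotoxicity, read by MTT assay, with a stated time of 72 h; a lower number here means that less compound is tolerated, a higher number that more compound is tolerated: compound 3 gives 467 ug/mL, though compound 2 sits within the scatter of it. The parent amine, compound 1 `Nc1sc2c(c1-c1nc3ccccc3s1)CCCC2`, gives 163 ug/mL, and the 4-chlorophenyl imine, compound 2 `Clc1ccc(/C=N/c2sc3c(c2-c2nc4ccccc4s2)CCCC3)cc1`, gives 397 ug/mL. The step from amine to imine was a 2.4-fold higher number from compound 1 to compound 2 (0.39 log units; beyond the scatter); the exchange of 4-chlorophenyl for 2-phenylethenyl on the imine carbon was a 1.2-fold higher number from compound 2 to compound 3 (0.07 log units; within the scatter). Compound 4 `Oc1ccccc1/C=N/c1sc2c(c1-c1nc3ccccc3s1)CCCC2` differs from compound 3 in one place: 2-hydroxyphenyl in place of 2-phenylethenyl on a carbon with a double bond to nitrogen. Both earlier steps bear on this: becoming an imine was modest, and a later swap of one group for another on that same carbon stayed within the scatter. Compound 4 keeps the imine and returns to a single aromatic ring, as compound 2 has, so the expected step of a 1.2-fold lower number from compound 3 to compound 4 (0.07 log units; within the scatter) is none beyond the scatter. Compound 4 is therefore estimated in this assay at 400 ug/mL, within 220 ug/mL to 720 ug/mL.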

Compound 4, half-maximal cytotoxic concentration: 114 ug/mL
Compound 4: middle estimate off by 3.5-fold (0.55 log units), on the high side, and the stated range ends above it.
By their numbers in this assay, from the lowest: compounds 4 and 1 (each within the scatter of the next); then compounds 2 and 3 (each within the scatter of the next).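

On the carbon with a double bond to nitrogen, the choice of group can matter in this assay: 2-hydroxyphenyl gives a 4.1-fold lower number from compound 3 to compound 4 (0.61 log units; beyond the scatter) and, compared with the 4-chlorophenyl imine, a 3.5-fold lower number from compound 2 to compound 4 (0.54 log units; beyond the scatter), whereas the earlier swap between the other two groups stayed within the scatter. Having an imine at this place therefore does not by itself go with a higher number, since the step from the parent amine is a 1.4-fold lower number from compound 1 to compound 4 (0.16 log units; within the scatter) and so stays within the scatter, unlike the rise seen for compound 2. Nothing available here explains why 2-hydroxyphenyl stands apart.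

As far as these compounds go, whether the lower number follows the hydroxyl group or the rest of the ring remains open. An imine carrying plain phenyl or 2-methoxyphenyl on that carbon would help separate the two.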